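Lengthening the Alkylamino Chain on the Pyridine-Type Core

This account rests on a few compounds, and the source may have more. Where it says the series, first, only, none or still open, it means among the compounds named here.

Measured so far in an in vitro assay on HEK-tsA201 cells for antagonist activity at Neuronal acetylcholine receptor; alpha3/beta4 (Homo sapiens), read by fluorescence and calcium flux; a lower number here means a stronger inhibitor, a higher number a weaker inhibitor:
- compound 1, `CCCOc1ccc(C(=O)Nc2cccc(C)n2)cc1`, gives 11100 nM
- compound 2, `CCCOc1ccc(C(=O)Nc2cccc(Br)n2)cc1`, gives a limit of the assay, > 100000 nM
- compound 3, `CCCCNc1cccc(NC(=O)c2ccc(OCCC)cc2)n1`, gives 77800 nM

Of the two compounds with a number, compound 3 stands highest, with compound 1 the nearest: a 7.0-fold higher number from compound 1 to compound 3 (0.85 log units; beyond the scatter). The value of compound 2 is only a limit (the limit of > 100000 nM in this assay, at which 1 of the 3 values shown sits), so it cannot be ordered against compound 3; all that can be said is an at least 1.2-fold lower number from compound 2 to compound 3 (0.10 log units; that floor lies within the scatter).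

Compound 4, `CCCCCNc1cccc(NC(=O)c2ccc(OCCC)cc2)n1`, is not yet measured. It differs from compound 3 by methyl in place of hydrogen on a saturated chain carbon, four bonds along the chain from a nitrogen on an aromatic ring. Both measured steps that touch this part of the shared core, a 7.0-fold higher number from compound 1 to compound 3 (0.85 log units; beyond the scatter) and an at least 1.2-fold lower number from compound 2 to compound 3 (0.10 log units; that floor lies within the scatter), swap one whole group for another, so neither measures what one extra chain carbon does. Among the compounds with values here, with no step of this kind to lean on, the change is expected to fall within the scatter, in no clear direction: the expected step is a 1.0-fold higher number from compound 3 to compound 4 (0.01 log units; within the scatter).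

Compound 4 is therefore estimated at 80000 nM, in the range 30000 nM to 200000 nM.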

Compound 4, half-maximal inhibitory concentration: > 100000 nM
Compound 4 gave a limit, no number; the forecaster's own chance of this, stated with the estimate: 35%; at least 1.2-fold (0.09 log units) between middle value and limit.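

In this assay compound 4 reaches a limit of the assay and gives no number, so methyl in place of hydrogen on this saturated chain carbon, four bonds along the chain from a nitrogen on an aromatic ring, can be read only as a floor: an at least 1.2-fold higher number from compound 3 to compound 4 (0.10 log units; that floor lies within the scatter). That floor shows no change beyond the scatter, yet the true step could be larger, so the extra chain carbon has no measured size here. The comparison with the methyl compound is firmer, with an at least 9.0-fold higher number from compound 1 to compound 4 (0.95 log units; beyond the scatter), which places pentylamino with butylamino on the weaker side of methyl, while the step between compound 2 and compound 4 cannot be read, as the assay's ceiling now bounds more of the series: the limit of > 100000 nM in this assay, at which 2 of the 4 values shown sit.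

As far as these compounds go, how far compound 4 lies past that limit stays unknown, and so does whether lengthening the chain weakens inhibition at all. Shorter groups at the same place, such as propylamino, ethylamino or a plain amine, could show whether any alkylamino group comes close to methyl.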